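A Ring-Bearing Carbonyl Gives Way to an Open Chain

The source may report more compounds than this note shows. Statements on the series, on what has been measured and on what is new or still open speak of the compounds shown alone.

Of the compounds shown here, three sharing one core have been tested in an ADME assay on CEM-SS cells (Homo sapiens) for cytotoxicity, read by XTT assay; on this read-out higher numbers stand for lower toxicity in this test and lower numbers for higher toxicity in this test. In this assay compound 1 `CN1CCN(Cc2cn(Cc3ccc(F)cc3)c3cnc(C(=O)N(C)O)cc23)CC1` gives > 224000 nM, which is a limit of the assay and not a number. Compound 2 `CN(O)C(=O)c1cc2c(CN3CCNC(=O)C3)cn(Cc3ccc(F)cc3)c2cn1` gives > 100000 nM, also a limit. Compound 3 `CN(O)C(=O)c1cc2c(C(=O)N3CCC[C@@H]3CO)cn(Cc3ccc(F)cc3)c2cn1` gives > 32000 nM, again a limit. None of the three results is an exact number, so compound 3 cannot be ranked against the other two.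

Compound 4 `COCCOCCCc1cn(Cc2ccc(F)cc2)c2cnc(C(=O)N(C)O)cc12` has not yet been measured. It differs from compound 3 in one place: 3-(2-methoxyethoxy)propyl in place of (2-(hydroxymethyl)pyrrolidin-1-yl)carbonyl on an aromatic carbon. An open 3-(2-methoxyethoxy)propyl chain thus stands in place of (2-(hydroxymethyl)pyrrolidin-1-yl)carbonyl on an aromatic carbon.

The nearest evidence comes from two changes at this same carbon: a step that the two limits leave unreadable from compound 1 to compound 3 and a step that the two limits leave unreadable from compound 2 to compound 3. The third comparison is a step that the two limits leave unreadable from compound 1 to compound 2. None of these steps has a size that can be read, and none brings in this open chain. They point in no direction, so no change beyond the scatter is expected. The estimated change, which sets a number against a limit and is therefore rough, is a step that the limit leaves unreadable from compound 3 to compound 4. The estimate for compound 4 is 50000 nM, with an expected range from 12000 nM to 200000 nM.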

Compound 4, half-maximal cytotoxic concentration: > 10000 nM
Compound 4 was reported as a limit; the forecaster's own chance of this, stated with the estimate: 60%; the middle value does not contradict the limit.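

In this assay compound 4 gives > 10000 nM, which is a limit of the assay and not a number. Going by these compounds alone, compound 1, compound 2 and compound 3 also carry only limits, so no step from any of them to compound 4 can be read. The compounds shown leave open whether replacing the group at this aromatic carbon changes the cytotoxic concentration at all.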